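A few compounds are considered here, and "the series" means these few. Any claim that something is new, unique, unknown or untested is made for them only; others in the source may bear on it.

Compound 1, `CCCCCCCCCCCCNc1nc(O)nc(O)c1N`, gives 300 nM in a functional assay (mitochondria, heart) with Bos taurus as the target; on this read-out higher numbers stand for weaker inhibition and lower numbers for stronger inhibition. Compound 2, `CCCCCCCCCCCCCCCCNc1nc(O)nc(O)c1N`, carries butyl in place of hydrogen on a saturated chain carbon, ten or more bonds along the chain from a nitrogen on an aromatic ring and gives 900 nM in this assay, so the step of a 3.0-fold higher number from compound 1 to compound 2 (0.48 log units; beyond the scatter) weakened inhibition. Compound 3, `CCCCCCCCCCCCn1c(O)nc2c(=O)[nH]c(=O)[nH]c21`, gives 1000 nM in this assay; the difference between its core and the core of compound 1 is not broken down here. Compound 4, `CCCCCCCCCCCCCCCCn1c(O)nc2c(=O)[nH]c(=O)[nH]c21`, differs from compound 3 by butyl in place of hydrogen on a saturated chain carbon, ten or more bonds along the chain from an aromatic nitrogen. The surroundings are described once as a nitrogen on an aromatic ring and once as an aromatic nitrogen, so this is the same kind of change rather than the same change. The step from compound 3 to compound 4 is expected to be a 2.5-fold higher number from compound 3 to compound 4 (0.40 log units; beyond the scatter), resting on the step of a 3.0-fold higher number from compound 1 to compound 2 (0.48 log units; beyond the scatter) made by the same kind of change. Compound 4 is therefore estimated at 2500 nM, expected to fall between 1200 nM and 6000 nM.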

Compound 4, half-maximal inhibitory concentration: 750 nM
Beside the measured number, compound 4's estimate is 3.3-fold (0.52 log units) above it, outside the stated range (below it).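

Butyl in place of hydrogen on the chain does not carry over from one core to the other in this assay, as the two steps differ by more than repeat measurements would explain: the same change on two cores in this assay, a 3.0-fold higher number (0.48 log units; beyond the scatter) from compound 1 to compound 2 and a 1.3-fold lower number (0.12 log units; within the scatter) from compound 3 to compound 4, 4.0-fold (0.60 log units) apart, beyond the scatter of two such steps. The new step, a 1.3-fold lower number from compound 3 to compound 4 (0.12 log units; within the scatter), shows no readable change on this core, so the weakening of inhibition seen on the core of compound 1 cannot be assumed for a different core. This single pair of steps shows that the outcome differs between these two cores, but it does not show why, nor how the change would behave on any third core.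

Going by these compounds, it remains open how either core responds to a shorter chain such as hexyl or octyl. Also open, on these data alone, is what happens when the chain carries an amine or a carboxylic acid.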